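Replacing 2-phenylpropyl with isopropyl in compound 2

This account rests on a few compounds, and the source may have more. Where it says the series, first, only, none or still open, it means among the compounds named here.

Measured in a functional assay on THP-1 cells (Homo sapiens) for inhibition, read by luminescence, with a stated time of 72 h, tested at 5 uM (on this read-out higher numbers stand for more inhibition of growth at the one concentration tested and lower numbers for less inhibition of growth), so far:
compound 1 `C=CS(=O)(=O)NC/C=C/c1cc(OC)cc(O)c1C(=O)OC(C)C` gives 19.9%
compound 2 `COc1cc(O)c(C(=O)OCC(C)c2ccccc2)c(/C=C/CN2C(=O)C=CC2=O)c1` gives 0%

Compound 2 stands lowest of the two, with compound 1 beyond the scatter above it. Compound 3 `COc1cc(O)c(C(=O)OC(C)C)c(/C=C/CN2C(=O)C=CC2=O)c1` carries isopropyl in place of 2-phenylpropyl on an oxygen next to a carbonyl group and awaits measurement. Compound 1 also carries isopropyl and gives 19.9% in this assay and so a modest rise is expected for this change. The estimated step of a number 14 percentage points higher from compound 2 to compound 3 (beyond the scatter) is expected to point upward and stay modest. For compound 3 the expected value is 14% (estimated range 0% to 40%).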

Compound 3, percent growth inhibition at one concentration: 41.8%
Compound 3: the middle estimate sits 27.8 percentage points below what was measured; measured number outside the range, above it.
By their numbers in this assay, from the lowest: compound 2; then compound 1; then compound 3.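

In this assay, the change of 2-phenylpropyl to isopropyl on an oxygen next to a carbonyl group gives a number 41.8 percentage points higher from compound 2 to compound 3 (beyond the scatter), so this position strongly affects growth inhibition. With isopropyl held constant, exchanging the sulfur-bearing chain group for the group with the five-membered non-aromatic ring gives a number 21.9 percentage points higher from compound 1 to compound 3 (beyond the scatter), so that second place also matters. Nothing available here explains either step. The compounds shown leave open how methyl or a longer chain such as n-butyl would behave on that oxygen.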